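Benzhydryl sulfoxides: heteroaryl swap at the methylene carbon

The source may hold more compounds than are shown below. What is called first, only, known or untested is meant among the compounds shown, and "the series" means these compounds.

Measured so far:
compound 1 `O=c1[nH]nc(C[S+]([O-])C(c2ccccc2)c2ccccc2)s1` — 38100 nM
compound 2 `[O-][S+](Cc1cccs1)C(c1ccc(Cl)cc1)c1ccc(Cl)cc1` — 7200 nM
compound 3 `COc1ccnc(C[S+]([O-])C(c2ccccc2)c2ccccc2)c1OC` — "not active" (no number reported)

In an assay on HEK293 cells for inhibition of sodium-dependent dopamine transporter (Homo sapiens), read by scintillation counting, with stated times of 5 min and 1 min (a higher number here means a weaker inhibitor, a lower number a stronger inhibitor), compound 1 gives 38100 nM, the highest number among the two compounds that report a value. Compound 2 gives the lower number, 7200 nM, and the gap between the two lies beyond the usual scatter. Compound 3 is reported as "not active" (no number reported), with no number attached, so it cannot be placed against the other two.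

Compound 4 `[O-][S+](Cc1csc(Br)c1)C(c1ccccc1)c1ccccc1` is the next entry. Relative to compound 1 the change is a group of 6 heavy atoms (4 carbon, 1 sulfur, 1 bromine; one five-membered aromatic ring with 1 hetero atom) in place of a group of 6 heavy atoms (2 carbon, 2 nitrogen, 1 oxygen, 1 sulfur; one five-membered aromatic ring with 3 hetero atoms), on a saturated chain carbon bound to a sulfur. Going by the values given here, no pair differing in one place has been measured, so the size of the step has to be expected rather than read off. Among the compounds with values here, the one hint is compound 2, which also carries a five-membered aromatic ring with one hetero atom on the saturated chain carbon bound to a sulfur and gives 7200 nM; its two chlorines are a second difference, so the hint is loose. A moderate drop in number, beyond the scatter, is expected in this assay. Compound 4 is estimated at 12000 nM, with a range from 4000 nM to 35000 nM. This estimate corresponds to an expected step of a 3.2-fold lower number from compound 1 to compound 4 (0.50 log units; beyond the scatter).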

Compound 4, half-maximal inhibitory concentration: 16600 nM
Estimate against measurement, compound 4: 1.4-fold (0.14 log units) below, and the stated range covers the measured number.
By their numbers in this assay, from the lowest: compound 2; then compound 4; then compound 1.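

In this assay, going by these compounds alone, the heteroaryl swap gives the first step that can be read at this position: a 2.3-fold lower number from compound 1 to compound 4 (0.36 log units; beyond the scatter) when 5-bromothiophen-3-yl replaces the group in compound 1 on the saturated chain carbon bound to a sulfur. The position therefore accepts a change of ring and hetero atoms at constant heavy-atom count, and the group entering carries 0 hydrogen-bond donors against 1 in the group leaving, with a modest gain in inhibition. No measured evidence accounts for this step.

Open, on these data alone, is how much of the step belongs to the bromine and how much to the ring that carries it. Also open, as far as these compounds go, is how the same position responds to a group of another kind, such as an amine or a carboxylic acid.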